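Swapping the Amide for a Triazole at the Ring Carbon

The compounds below may be only part of what the source reports. "The series", "measured", "known", "first", "only" and "open" are said of these compounds alone.

Three compounds share one core and differ only in the group on the saturated six-membered ring. Compound 1 `N#Cc1cnc(NCc2cnccc2C(F)(F)F)cc1N[C@H]1CC[C@@H](O)CC1` carries a hydroxy group there; in an assay on isolated protein for inhibition of protein kinase C delta type (Homo sapiens), read by TR-FRET, with a stated time of 2 h (a lower number here means a stronger inhibitor, a higher number a weaker inhibitor), compound 1 gives 4500 nM. Compound 2 `CO[C@H]1CC[C@@H](Nc2cc(NCc3cnccc3C(F)(F)F)ncc2C#N)CC1` carries a methoxy group instead, and in this assay compound 2 gives 5000 nM; the step of a 1.1-fold higher number from compound 1 to compound 2 (0.05 log units; within the scatter) shows that this swap changed little. Compound 3 `CN(C)C(=O)[C@H]1CC[C@@H](Nc2cc(NCc3cnccc3C(F)(F)F)ncc2C#N)CC1` carries a dimethylcarbamoyl group, and in this assay compound 3 gives 1800 nM, the lowest of the three numbers. The steps of a 2.5-fold lower number from compound 1 to compound 3 (0.40 log units; beyond the scatter) and a 2.8-fold lower number from compound 2 to compound 3 (0.44 log units; beyond the scatter) both run in the same direction and are modest in size.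

Compound 4 `N#Cc1cnc(NCc2cnccc2C(F)(F)F)cc1N[C@H]1CC[C@@H](n2cncn2)CC1` has not yet been measured. It differs from compound 3 in one place: 1H-1,2,4-triazol-1-yl in place of dimethylcarbamoyl on a saturated ring carbon. Among the compounds with values here, no measured step involves a triazole, so the two measured steps bear on it only loosely: they show that the group on this ring carbon can move the number by a modest amount, and that the dimethylcarbamoyl group gave the lowest number so far. The triazole is a different kind of group, so the expected step of a 1.7-fold higher number from compound 3 to compound 4 (0.22 log units; within the scatter) is small and its direction is uncertain. Compound 4 is therefore expected to give about 3000 nM in this assay, with a likely range from 1000 nM to 9000 nM.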

Compound 4, half-maximal inhibitory concentration: 5500 nM
Beside the measured number, compound 4's estimate is 1.8-fold (0.26 log units) below it; measured number inside the range.
By their numbers in this assay, from the lowest: compound 3; then compounds 1, 2 and 4 (each within the scatter of the next).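

In this assay, the change to 1H-1,2,4-triazol-1-yl gives a 3.1-fold higher number from compound 3 to compound 4 (0.49 log units; beyond the scatter), so the low number of compound 3 does not carry over to any group of the same heavy-atom count placed on this saturated ring carbon. The triazole also brings more hydrogen-bond acceptors than dimethylcarbamoyl, yet this pair shows no gain from that higher count. Compound 4 instead falls in with the two simpler compounds, with a 1.1-fold higher number from compound 2 to compound 4 (0.04 log units; within the scatter) and a 1.2-fold higher number from compound 1 to compound 4 (0.09 log units; within the scatter), which leaves hydroxy, methoxy and the triazole indistinguishable here and makes compound 3, with its dimethylcarbamoyl group, the only one of the four that stands apart.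

No measurement shown explains why dimethylcarbamoyl differs from the other three groups at this position. From the compounds shown here alone, it also remains open whether the advantage belongs to amides more widely, which a primary carboxamide or a pyrrolidine amide could test, and how a carboxylic acid or an amine on the same ring carbon would compare with compound 3.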